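Changing the Aryl Group: From Compound 3 to Compound 4

The source may hold more compounds than are shown below. What is called first, only, known or untested is meant among the compounds shown, and "the series" means these compounds.

Compound 1 `COc1nc2ccc(Br)cc2cc1C(c1ccccc1)n1cc(-c2ccccc2)nn1`: 30.1%
Compound 2 `CCCCc1cn(C(c2ccccc2)c2cc3cc(Br)ccc3nc2OC)nn1`: 5.46%
Compound 3 `COc1nc2ccc(Br)cc2cc1C(c1ccccc1)n1cc(-c2ccccc2F)nn1`: 14.7%

All three were tested in an ADME assay on PANC-1 cells (Homo sapiens) for cytotoxicity, read by sulforhodamine B assay, with a stated time of 48 h, tested at 10 uM; a higher number here means more inhibition at the concentration tested (going by the name of the read-out), a lower number less inhibition. Compound 3 stands second highest of the three numbers. Its nearest neighbour is compound 2, which gives 5.46%, a difference within the scatter. Farthest from it is compound 1, which gives 30.1%, the step of a number 15.4 percentage points lower from compound 1 to compound 3 (beyond the scatter) being beyond the scatter.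

Compound 4 `COc1nc2ccc(Br)cc2cc1C(c1ccccc1)n1cc(-c2ccc(OC(F)(F)F)cc2)nn1` has not yet been measured. It differs from compound 3 in one place: 4-(trifluoromethoxy)phenyl in place of 2-fluorophenyl on an aromatic carbon.

Among the compounds with values here, two measured steps touch the same aromatic carbon. The step of a number 15.4 percentage points lower from compound 1 to compound 3 (beyond the scatter) shows that adding fluoro to the phenyl lowered inhibition modestly. The step of a number 9.2 percentage points higher from compound 2 to compound 3 (within the scatter) shows that 2-fluorophenyl and butyl give numbers within the scatter of each other. Within the data shown here, no measured compound carries 4-(trifluoromethoxy)phenyl, so its effect is uncertain. Compound 4 is therefore expected to stay in the range spanned by compounds 1 to 3, with the step of a number 2.3 percentage points higher from compound 3 to compound 4 (within the scatter) expected to lie within the scatter. The estimated value for compound 4 is 17%, ranging from 4% to 32%.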

Compound 4, a percentage reported as inhibition, at one concentration (the size of the read-out at that concentration, not a potency): 11.7%
Compound 4: middle estimate off by 5.3 percentage points, on the high side; low and high end bracket the measured number.
By their numbers in this assay, from the lowest: compounds 2, 4 and 3 (each within the scatter of the next); then compound 1.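

In this assay, the step of a number 3 percentage points lower from compound 3 to compound 4 (within the scatter) shows that exchanging 2-fluorophenyl for the larger 4-(trifluoromethoxy)phenyl on this aromatic carbon of the five-membered ring makes no clear difference, and the step of a number 6.2 percentage points higher from compound 2 to compound 4 (within the scatter) likewise leaves this group level with butyl. The step of a number 18.4 percentage points lower from compound 1 to compound 4 (beyond the scatter) gives a second substituted phenyl that falls clearly short of the plain phenyl, so among the compounds shown, the unsubstituted ring alone stands apart, with no compound going against this. Nothing measured here explains why the plain phenyl differs from the other three groups.

Going by these compounds, whether 4-fluorophenyl would match 2-fluorophenyl remains open, so the effect of where a substituent sits cannot be separated from the effect of which substituent it is. Also open, on these data alone, is whether a phenyl ring bearing an amine or a carboxylic acid would give a number nearer that of compound 1.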